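This account rests on a few compounds, and the source may have more. Where it says the series, first, only, none or still open, it means among the compounds named here.

Values in a functional assay (brain) for inhibition, with Rattus norvegicus as the target; a lower number here means a stronger inhibitor, a higher number a weaker inhibitor:
- compound 1 `CCCCCCCCCCCCCCCCCCOC1=C(O)OC(C2COC(C)(C)O2)C1=O`: 2400 nM
- compound 2 `CCCCCCCCCCCCCCCCCCOC1=C(O)OC(C(O)COC(C)=O)C1=O`: 4200 nM

On these two numbers, compound 2, at 4200 nM, lies within the scatter of compound 1, so the pair gives no ranking.

The next compound to be read is compound 3 `CCCCCCCCCCCCCCCCCCOC1=C(O)OC(CCO)C1=O`, which has 2-hydroxyethyl in place of 2-acetoxy-1-hydroxyethyl on a saturated ring carbon. The rest of the structure is shared.

Going by the values given here, only one measured step bears on this change. a 1.8-fold higher number from compound 1 to compound 2 (0.24 log units; within the scatter) involves a different exchange, but on the same saturated ring carbon, and it stays within the scatter. That single step shows a large change of group at this carbon without a clear shift in this assay. Among the compounds with values here, it says little about a group as short as 2-hydroxyethyl, and the data hold no direct precedent for one. No step beyond the scatter is therefore expected, and no direction is favoured with confidence.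

The expected step is a 1.2-fold lower number from compound 2 to compound 3 (0.08 log units; within the scatter). For compound 3 the estimated value is 3500 nM, with an expected range of 1400 nM to 9000 nM.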

Compound 3, half-maximal inhibitory concentration: 6800 nM
For compound 3 the middle estimate is 1.9-fold (0.29 log units) below the measured one, within the range that was stated.
By their numbers in this assay, from the lowest: compounds 1, 2 and 3 (each within the scatter of the next, the first and the last beyond it).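

In this assay, 2-hydroxyethyl in place of 2-acetoxy-1-hydroxyethyl gives a 1.6-fold higher number from compound 2 to compound 3 (0.21 log units; within the scatter), so this pair yields no ranking, although the entering group has 3 heavy atoms and the leaving group has 7. Going by these compounds alone, the first step beyond the scatter at this saturated ring carbon appears only between the two ends of the set, with 2-hydroxyethyl in place of 2,2-dimethyl-1,3-dioxolan-4-yl, and it is a modest one: a 2.8-fold higher number from compound 1 to compound 3 (0.45 log units; beyond the scatter). Compound 2 lies within the scatter of both other compounds, so the position tolerates all three groups with only a modest spread in this assay, and no information is available on what lies behind that spread.

The compounds shown leave open whether an amine, a carboxylic acid or a longer chain ending in hydroxy on this carbon would extend that spread, and in which direction. All three compounds share the rest of the structure, so they say nothing about how a change elsewhere in the core or its long chain would read in this assay.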